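Swapping Fluorines for Chlorines on the Sulfonyl Aryl Ring

This account rests on a few compounds, and the source may have more. Where it says the series, first, only, none or still open, it means among the compounds named here.

The measured compounds:
compound 1 `COc1cccc(-c2c(S(=O)(=O)c3cc(F)cc(F)c3)cnc3cc(F)ccc23)c1`: 1.81 mL/min
compound 2 `O=S(=O)(c1cc(F)cc(F)c1)c1cnc2cc(F)ccc2c1-c1cccc(Cl)c1`: 0.22 mL/min
compound 3 `O=S(=O)(c1cc(F)cc(F)c1)c1cnc2cc(F)ccc2c1-c1cccc(F)c1`: 0.06 mL/min

In an ADME assay on microsomes from liver (Homo sapiens) for metabolic stability, tested at 2.5 uM (on this read-out higher numbers stand for fast clearance and lower numbers for slow clearance), compound 2 stands second highest of the three, with compound 3 nearest and compound 1 furthest from it: a 3.7-fold lower number from compound 2 to compound 3 (0.56 log units; beyond the scatter) and an 8.2-fold lower number from compound 1 to compound 2 (0.92 log units; beyond the scatter).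

Compound 4 `O=S(=O)(c1cc(Cl)cc(Cl)c1)c1cnc2cc(F)ccc2c1-c1cccc(Cl)c1` is not yet measured. It differs from compound 2 in one place: 3,5-dichlorophenyl in place of 3,5-difluorophenyl on a sulfonyl sulfur.

Among the measured compounds shown here, no measured step changes the group on the sulfonyl sulfur. For the measured compounds named here, the only step that trades fluoro against chloro anywhere is the one from compound 2 to compound 3, a 3.7-fold lower number from compound 2 to compound 3 (0.56 log units; beyond the scatter), which runs toward the lower number; the reverse trade, carried out twice on the other ring, suggests a step in this assay back toward higher numbers, of modest size and uncertain.

Compound 4 is therefore expected to give about 0.6 mL/min, a step of a 2.7-fold higher number from compound 2 to compound 4 (0.44 log units; beyond the scatter).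

The expected range for compound 4 runs from 0.2 mL/min to 1.8 mL/min.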

Compound 4, intrinsic clearance in a liver preparation (reported as CLH), per the amount of preparation that the assay uses: 0.93 mL/min
Compound 4: the middle estimate sits 1.6-fold (0.19 log units) below what was measured, within the range that was stated.
By their numbers in this assay, from the lowest: compound 3; then compound 2; then compounds 4 and 1 (each within the scatter of the next).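

In this assay, the group on the sulfonyl sulfur proves able to shift the read-out: 3,5-dichlorophenyl in place of 3,5-difluorophenyl gives a 4.2-fold higher number from compound 2 to compound 4 (0.63 log units; beyond the scatter). The earlier compounds changed only the other ring, and in both single-place trades shown the chloro compound carries the higher number, the other being a 3.7-fold lower number from compound 2 to compound 3 (0.56 log units; beyond the scatter). No measurement shown accounts for this step.

From the compounds shown here alone, it remains open how a phenyl carrying an amine or a carboxylic acid on the sulfonyl sulfur would read in this assay. Also open, going by these compounds, is whether 3,5-dichlorophenyl would give a similar step alongside the other ring of compound 3.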